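Moving one methoxy group on the amide-bound ring

The source may report more compounds than this note shows. Statements on the series, on what has been measured and on what is new or still open speak of the compounds shown alone.

Of the compounds shown here, two have been measured in an in vitro assay on BTI-TN-5B1-4 cells for inhibition of Amine oxidase [flavin-containing] B (Homo sapiens), read by fluorescence (a lower number here means a stronger inhibitor, a higher number a weaker inhibitor), so far. Compound 1 `Cc1cccc(Cl)c1NC(=O)c1cc2ccc(OCc3ccc(F)cc3)cc2oc1=O` gives 41600 nM in this assay. Compound 2 `COc1ccc(NC(=O)c2cc3ccc(OCc4ccc(F)cc4)cc3oc2=O)cc1OC` gives 2870 nM in this assay, the lowest of the two numbers. Among the compounds with values here, the one measured step, a 14-fold lower number from compound 1 to compound 2 (1.16 log units; beyond the scatter), shows that exchanging the ring on the amide-type nitrogen can shift the result substantially.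

Compound 3 `COc1cc(NC(=O)c2cc3ccc(OCc4ccc(F)cc4)cc3oc2=O)cc(OC)c1` has not been measured in this assay. It differs from compound 2 only in the position of one methoxy group on that ring: 3,5-dimethoxyphenyl in place of 3,4-dimethoxyphenyl on an amide-type nitrogen. Within the data shown here, the measured step from compound 1 to compound 2 exchanged the whole ring; no measured pair rearranges substituents on an otherwise identical ring, so it offers no direct guide to the size or direction of this smaller change. The expectation is therefore a step of a 1.2-fold higher number from compound 2 to compound 3 (0.09 log units; within the scatter) in this assay, that is, no change beyond the scatter, with a broad range to cover either direction. Compound 3 is expected to give about 3500 nM in this assay, estimated to fall between 1200 nM and 10000 nM.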

Compound 3, half-maximal inhibitory concentration: 21600 nM
The estimate for compound 3 lay 6.2-fold (0.79 log units) below the measured number; the whole stated range lies below it.
By their numbers in this assay, from the lowest: compound 2; then compounds 3 and 1 (each within the scatter of the next).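

With the same atoms on the ring, shifting one methoxy group alone changes the result in this assay: 3,5-dimethoxyphenyl in place of 3,4-dimethoxyphenyl on the amide-type nitrogen gives a 7.5-fold higher number from compound 2 to compound 3 (0.88 log units; beyond the scatter) on the otherwise unchanged compound. The arrangement of the groups on this ring therefore goes with the result, and not only their kind and number, which the earlier exchange of a whole ring could not separate. The other new comparison shows a 1.9-fold lower number from compound 1 to compound 3 (0.28 log units; within the scatter) for 3,5-dimethoxyphenyl in place of 2-chloro-6-methylphenyl, so these two rings cannot be told apart here, and among the three compounds only the 3,4-dimethoxyphenyl ring of compound 2 stands out.

Nothing available explains why the place of one methoxy group counts for so much.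

From the compounds shown here alone, it also remains open whether a ring carrying a single methoxy group, or an ethoxy group, a hydroxyl group or an amine in place of a methoxy group, would keep the lower number of compound 2 or lose it.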